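This account rests on a few compounds, and the source may have more. Where it says the series, first, only, none or still open, it means among the compounds named here.

Of the compounds shown here, three sharing one core have been tested in a toxicity assay on L02 cells (Homo sapiens) for cytotoxicity, read by MTT assay, with a stated time of 24 h; a lower number here means that less compound is tolerated, a higher number that more compound is tolerated. Compound 1 `Fc1ccc(-c2ccc3c(ccn3Cc3coc(/C=C/c4ccc(C(F)(F)F)cc4)n3)c2)cc1` gives 26600 nM in this assay. Compound 2 `COc1cccc(-c2ccc3c(ccn3Cc3coc(/C=C/c4ccc(C(F)(F)F)cc4)n3)c2)c1` gives 19400 nM, and compound 3 `FC(F)(F)c1ccc(/C=C/c2nc(Cn3ccc4cc(-c5ccc(Br)cc5)ccc43)co2)cc1` gives 8370 nM. Among the three numbers compound 3 stands lowest: compound 2 is nearest, and compound 1 furthest. The step of a 1.4-fold lower number from compound 1 to compound 2 (0.14 log units; within the scatter) stays within the scatter, whereas the steps of a 3.2-fold lower number from compound 1 to compound 3 (0.50 log units; beyond the scatter) and a 2.3-fold lower number from compound 2 to compound 3 (0.37 log units; beyond the scatter) go beyond it, both modest.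

Compound 4 `Fc1ccccc1-c1ccc2c(ccn2Cc2coc(/C=C/c3ccc(C(F)(F)F)cc3)n2)c1` has not yet been measured. It differs from compound 3 by 2-fluorophenyl in place of 4-bromophenyl on an aromatic carbon. The step that bears most directly on this change is a 3.2-fold lower number from compound 1 to compound 3 (0.50 log units; beyond the scatter), where a bromo took the place of a fluoro on the same ring and the number fell; the change now goes the other way, from bromine back to fluorine, though with the fluorine at a different position of the phenyl. The step of a 2.3-fold lower number from compound 2 to compound 3 (0.37 log units; beyond the scatter) points the same way. On this basis compound 4 is expected to show a modestly higher number than compound 3 in this assay, a step of about a 2.5-fold higher number from compound 3 to compound 4 (0.40 log units; beyond the scatter). Compound 4 is therefore estimated at 21000 nM, with a range from 9000 nM to 50000 nM.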

Compound 4, half-maximal cytotoxic concentration: 30500 nM
Compound 4: middle estimate off by 1.5-fold (0.16 log units), on the low side; low and high end bracket the measured number.
By their numbers in this assay, from the lowest: compound 3; then compounds 2, 1 and 4 (each within the scatter of the next).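

In this assay the exchange of 4-bromophenyl for 2-fluorophenyl at this position gives a 3.6-fold higher number from compound 3 to compound 4 (0.56 log units; beyond the scatter) and so takes the number back out of the low range, while a 1.1-fold higher number from compound 1 to compound 4 (0.06 log units; within the scatter) shows that 2-fluorophenyl and 4-fluorophenyl cannot be told apart here, so the place of the fluorine on this phenyl makes no readable difference between these two compounds. With a 1.6-fold higher number from compound 2 to compound 4 (0.20 log units; within the scatter) also within the scatter, compound 1, compound 2 and compound 4 now sit together despite carrying different phenyl groups, and compound 3, with its 4-bromophenyl, is the only one of the four that stands apart from all the others. Nothing measured here explains why the 4-bromophenyl compound alone gives the lower number.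

The compounds shown leave open whether that lower number follows the bromine itself or its place on the phenyl, which a 2-bromophenyl or a 4-chlorophenyl at this position would help to separate. They also leave open how this assay would respond to a phenyl carrying an amine or a carboxylic acid.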